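This account rests on a few compounds, and the source may have more. Where it says the series, first, only, none or still open, it means among the compounds named here.

Working notes on the series. Compound 1 `N#CC1=C(N)N(c2ccc(S(N)(=O)=O)cc2)C2=C(CCCC2)C1c1ccccc1Cl` gives 0% in a functional assay on Ehrlich cells (Mus musculus) for cytotoxicity, read by trypan blue exclusion, with a stated time of 2 h, tested at 10 ug/mL; a higher number here means a stronger effect of the compound at the concentration tested, a lower number a weaker effect. Compound 2 `N#CC1=C(N)N(c2ccc(S(N)(=O)=O)cc2)C2=C(CCCC2)C1c1c(O)ccc2ccccc12` gives 10% in this assay, and the change a number 10 percentage points higher from compound 1 to compound 2 (within the scatter) leaves the two values within the scatter of each other. Compound 3 `COc1ccc2ccccc2c1C1C(C#N)=C(N)N(c2ccc(S(N)(=O)=O)cc2)C2=C1CCCC2` differs from compound 2 by methyl in place of hydrogen on an oxygen on an aromatic ring. Among the compounds with values here, no measured step touches this oxygen; the only step known, a number 10 percentage points higher from compound 1 to compound 2 (within the scatter), alters a different group and stays within the scatter. The expected step of no change at the digits printed from compound 2 to compound 3 (within the scatter) is therefore none beyond the scatter. Compound 3 is estimated at 10% in this assay, within 0% to 25%.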

Compound 3, a percentage reported as activity, at one concentration (the size of the read-out at that concentration, not a potency): 5%
For compound 3 the middle estimate is 5 percentage points above the measured one; low and high end bracket the measured number.
By their numbers in this assay, from the lowest: compounds 1, 3 and 2 (each within the scatter of the next).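

In this assay, within the data shown here, the change from hydroxy to methoxy gives a number 5 percentage points lower from compound 2 to compound 3 (within the scatter) and is the first reading at this oxygen on an aromatic ring. Replacing the hydrogen there with methyl therefore leaves the read-out within the scatter, so this oxygen hydrogen is not shown to be needed for the effect at the concentration tested. No measurement on hand offers an explanation for this result.

Still open, on these data alone, is whether a longer chain on this oxygen would move the read-out beyond the scatter. As far as these compounds go, an amine or a carboxylic acid in place of the hydroxy group also remains open.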